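Ring contraction on the acetamido side of compound 2

A few compounds are considered here, and "the series" means these few. Any claim that something is new, unique, unknown or untested is made for them only; others in the source may bear on it.

Measured in an ADME assay on microsomes from liver (Homo sapiens) for metabolic stability; a higher number here means faster removal of the compound, a lower number slower removal:
- Compound 1 `CC(=O)N[C@@H]1CCC[C@H](C(=O)Nc2cc(-c3cnn4c3CCC4)c(Cl)cn2)C1` gives < 3 mL.min-1.g-1 (a limit)
- Compound 2 `CC(=O)N[C@@H]1CCC[C@H](C(=O)Nc2cc(-c3cnn4c3CC(C)(C)C4)c(Cl)cn2)C1` gives 50 mL.min-1.g-1 (one entry)
- Compound 3 `CC(=O)N[C@@H]1CCC[C@H](C(=O)Nc2cc(-c3cnn4c3CC(C)C4)c(Cl)cn2)C1` gives 13 mL.min-1.g-1; 18 mL.min-1.g-1 (2 entries) (two entries)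

The entry for compound 1 is a limit of the assay and not a number (see (the limit of < 3 mL.min-1.g-1 in this assay, at which 1 of the 3 values shown sits)). Within the data shown here, compound 2, at 50 mL.min-1.g-1, is the only compound here with a single number. Compound 4 `CC(=O)N[C@@H]1CC[C@H](C(=O)Nc2cc(-c3cnn4c3CC(C)(C)C4)c(Cl)cn2)C1` carries 3-acetamidocyclopentyl in place of 3-acetamidocyclohexyl on a carbonyl carbon. Among the measured compounds shown here, the one measured step (an at least 16-fold higher number from compound 1 to compound 2 (1.22 log units; beyond the scatter)) was large, but it lies on an aromatic carbon and leaves this group untouched. For the measured compounds named here, no measured step changes this ring, so in this assay no shift beyond the scatter is expected, with a slight lean towards a lower number. The expected step is small (a 1.4-fold lower number from compound 2 to compound 4 (0.15 log units; within the scatter)). For compound 4 the estimate is 35 mL.min-1.g-1, with an expected range from 15 mL.min-1.g-1 to 75 mL.min-1.g-1 in this assay.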

Compound 4, intrinsic clearance in microsomes: 38 mL.min-1.g-1
Compound 4: the middle estimate sits 1.1-fold (0.04 log units) below what was measured; low and high end bracket the measured number.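

In this assay, among these compounds, the first measured step on this carbonyl carbon, 3-acetamidocyclopentyl in place of 3-acetamidocyclohexyl, gives a 1.3-fold lower number from compound 2 to compound 4 (0.12 log units; within the scatter). Contracting this ring therefore does not shift the number beyond the scatter, whereas the step on the aromatic carbon gives an at least 16-fold higher number from compound 1 to compound 2 (1.22 log units; beyond the scatter). Nothing available here offers a cause for this outcome.

The compounds shown leave open whether the number would also hold with a carboxylic acid or an amine in place of the acetamido group. They also leave open whether the same contraction would behave alike on the core of compound 1.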